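The source may report more compounds than this note shows. Statements on the series, on what has been measured and on what is new or still open speak of the compounds shown alone.

Compound 1 `COc1cccc(NC(=S)N/N=C/c2ccc3ccccc3n2)c1` gives 82400 nM.
Compound 2 `CN(C)C(=S)N/N=C/c1cnc2ccccc2n1` gives 450 nM.
Compound 3 `NC(=S)N/N=C/c1cc2cccnc2s1` gives > 100000 nM.

In a functional assay on HT-29 cells (Homo sapiens) for antiproliferative activity, read by sulforhodamine B assay, with a stated time of 72 h (a higher number here means a weaker inhibitor, a lower number a stronger inhibitor), compound 1 stands at the higher of the two measured numbers, so it is the weaker inhibitor of the pair; compound 2 sits at a far lower number, a gap beyond the usual scatter. The value of compound 3 is a limit of the assay, not a number. Compound 4 `S=C(N/N=C/c1ccc2ccccc2n1)Nc1ccc(Cl)cc1` differs from compound 1 in one place: 4-chlorophenyl in place of 3-methoxyphenyl on an amide-type nitrogen. Going by the values given here, no measured pair here shows what such a change does. The step expected from compound 1 to compound 4 is a 1.5-fold lower number from compound 1 to compound 4 (0.18 log units; within the scatter), which is not beyond the scatter. Compound 4 is therefore estimated at 55000 nM, with a range from 15000 nM to 160000 nM.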

Compound 4, half-maximal inhibitory concentration: 97200 nM
Beside the measured number, compound 4's estimate is 1.8-fold (0.25 log units) below it, and the stated range covers the measured number.
By their numbers in this assay, from the lowest: compound 2; then compounds 1 and 4 (each within the scatter of the next). At a limit, above all of these: compound 3.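

In this assay, 4-chlorophenyl in place of 3-methoxyphenyl on this amide-type nitrogen gives a 1.2-fold higher number from compound 1 to compound 4 (0.07 log units; within the scatter), so the two groups cannot be told apart here. Going by these compounds alone, this is the first direct reading at this position, and it shows that this swap of one substituted phenyl ring for another leaves compound 4 as weak as compound 1. Little room remains for reading any further loss: the limit of > 100000 nM in this assay, at which 1 of the 4 values shown sits.

On these data alone, whether a carboxylic acid or a dimethylamino group on the phenyl ring would move the number remains open. So does whether either phenyl group would behave the same way on the core of compound 2.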